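Trimming the side chain of compound 1

The source may hold more compounds than are shown below. What is called first, only, known or untested is meant among the compounds shown, and "the series" means these compounds.

Measured in a functional assay on the whole organism for inhibition, with Oryza sativa as the target, with a stated time of 24 h; a lower number here means a stronger inhibitor, a higher number a weaker inhibitor:
- compound 1 `CC1=CC(=O)CC(C)(C)[C@@]1(O)/C=C/C(C)=C\C(=O)N[C@@H](CC(N)=O)C(=O)O` gives 9300 nM
- compound 2 `CC1=CC(=O)CC(C)(C)[C@@]1(O)/C=C/C(C)=C\C(=O)N[C@@H](CCC(N)=O)C(=O)O` gives 8300 nM

Among the compounds with values here, only two compounds have been measured so far, and compound 1 stands level with compound 2 in this assay. Within the data shown here, the one measured step is a 1.1-fold lower number from compound 1 to compound 2 (0.05 log units; within the scatter), so the two cannot be told apart on these numbers. Compound 3 `CC1=CC(=O)CC(C)(C)[C@@]1(O)/C=C/C(C)=C\C(=O)NCC(=O)O` shares the core of compound 1 and has no value yet. The change that leads to it is hydrogen in place of carbamoylmethyl on a saturated chain carbon bound to an amide-type nitrogen and a carbonyl carbon. The carbamoylmethyl group goes, and a hydrogen takes its place on the same saturated chain carbon.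

The measured step bears on this only in part. Among the measured compounds shown here, it altered the group at that carbon, whereas compound 3 loses the group altogether, and no measured compound shows what that does. Still, the group could be altered with no visible effect, as the step of a 1.1-fold lower number from compound 1 to compound 2 (0.05 log units; within the scatter) shows, so no step beyond the scatter is expected in this assay. The expected change is a 1.1-fold higher number from compound 1 to compound 3 (0.03 log units; within the scatter). For compound 3 the estimated value is 10000 nM, with a wide expected range from 4000 nM to 25000 nM.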

Compound 3, half-maximal inhibitory concentration: 5700 nM
Compound 3: middle estimate off by 1.8-fold (0.24 log units), on the high side, and the stated range covers the measured number.
By their numbers in this assay, from the lowest: compounds 3, 2 and 1 (each within the scatter of the next).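

Compound 3 shows what the earlier pair could not: the same saturated chain carbon can lose its side group entirely, not merely have it altered, without the number in this assay moving beyond the scatter (a 1.6-fold lower number from compound 1 to compound 3 (0.21 log units; within the scatter)). The comparison with the longer side group reads the same way (a 1.5-fold lower number from compound 2 to compound 3 (0.16 log units; within the scatter)), so neither carbamoylmethyl nor 2-carbamoylethyl can be told apart from a plain hydrogen at this carbon, and the amide end of these side groups has no visible effect on the result in this set of three compounds. No independent measurement is available to explain this lack of separation.

The compounds shown leave open whether any group at this carbon can move the number beyond the scatter, since they do not show a simple methyl, a longer carbon chain, or a chain ending in a carboxylic acid or an amine there. They also cannot say whether the same freedom would hold for changes elsewhere on the shared core, which stays the same in all three compounds.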